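A few compounds are considered here, and "the series" means these few. Any claim that something is new, unique, unknown or untested is made for them only; others in the source may bear on it.

In a functional assay on THP-1 cells (Homo sapiens) for inhibition, read by ELISA, with stated times of 1 h and 18 h (on this read-out lower numbers stand for stronger inhibition and higher numbers for weaker inhibition), three compounds that share one core and differ in a single aromatic group have been measured. Compound 1 `NC(=O)[C@@H]1[C@H](Nc2nc(Nc3cccc(C(=O)N4CCCC4)c3)ncc2-c2ccncc2)[C@H]2C=C[C@@H]1C2`, with pyridin-4-yl, gives 320 nM. Compound 2 `NC(=O)[C@@H]1[C@H](Nc2nc(Nc3cccc(C(=O)N4CCCC4)c3)ncc2-c2ccccc2F)[C@H]2C=C[C@@H]1C2`, with 2-fluorophenyl, gives 130 nM. Compound 3 `NC(=O)[C@@H]1[C@H](Nc2nc(Nc3cccc(C(=O)N4CCCC4)c3)ncc2-c2cncc(F)c2)[C@H]2C=C[C@@H]1C2`, with 5-fluoropyridin-3-yl, gives 170 nM.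

Compound 3 cannot be separated from either of the others: the data show a 1.9-fold lower number from compound 1 to compound 3 (0.27 log units; within the scatter) and a 1.3-fold higher number from compound 2 to compound 3 (0.12 log units; within the scatter). Only a 2.5-fold lower number from compound 1 to compound 2 (0.39 log units; beyond the scatter) exceeds the scatter, and it is modest.

Compound 4 `NC(=O)[C@@H]1[C@H](Nc2nc(Nc3cccc(C(=O)N4CCCC4)c3)ncc2-c2ccnc(F)c2)[C@H]2C=C[C@@H]1C2` has the same atoms as compound 3, joined differently: 2-fluoropyridin-4-yl in place of 5-fluoropyridin-3-yl on an aromatic carbon. Here 2-fluoropyridin-4-yl stands in place of 5-fluoropyridin-3-yl on an aromatic carbon. Within the data shown here, no measured step isolates this exchange. The nearest evidence is the small size of the steps among these three groups, so no change beyond the scatter is expected in this assay.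

The estimate is a 1.1-fold higher number from compound 3 to compound 4 (0.02 log units; within the scatter). For compound 4 the expected value is 180 nM, with an estimated range from 75 nM to 420 nM.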

Compound 4, half-maximal inhibitory concentration: 100 nM
Estimate against measurement, compound 4: 1.8-fold (0.26 log units) above; measured number inside the range.
By their numbers in this assay, from the lowest: compounds 4, 2, 3 and 1 (each within the scatter of the next, the first and the last beyond it).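

In this assay the same atoms joined as 2-fluoropyridin-4-yl instead of 5-fluoropyridin-3-yl give a 1.7-fold lower number from compound 3 to compound 4 (0.23 log units; within the scatter) and so stay unresolved, and the exchange of 2-fluorophenyl for 2-fluoropyridin-4-yl gives a 1.3-fold lower number from compound 2 to compound 4 (0.11 log units; within the scatter) with the same outcome. At this position, ortho to a large group, the three fluorine-bearing groups therefore cannot be told apart. The new information is that fluoro in place of hydrogen on pyridin-4-yl gives a 3.2-fold lower number from compound 1 to compound 4 (0.51 log units; beyond the scatter) as a single-atom change, although compound 3, which also carries fluoro, stays within the scatter of compound 1.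

On these data alone, it remains open whether chloro or methoxy in place of that fluoro would give a step of similar size, and where unsubstituted pyridin-3-yl would fall. Nothing given here explains these differences.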